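Furan-for-thiophene swap on the hydroxyphenyl pyridine series

The compounds below may be only part of what the source reports. "The series", "measured", "known", "first", "only" and "open" are said of these compounds alone.

Four compounds share one core built from a six-membered aromatic ring with one nitrogen carrying a phenyl group, a hydroxyphenyl group and a five-membered heteroaryl group. Compound 1 `Oc1ccc(-c2cc(-c3ccccc3)cc(-c3ccsc3)n2)cc1` carries a 4-hydroxyphenyl group and thiophen-3-yl; compound 2 `Oc1ccc(-c2cc(-c3ccccc3)cc(-c3ccco3)n2)cc1` carries furan-2-yl in its place. Compound 3 `Oc1cccc(-c2cc(-c3ccccc3)nc(-c3ccsc3)c2)c1` carries a 3-hydroxyphenyl group with thiophen-3-yl, and compound 4 `Oc1cccc(-c2cc(-c3ccccc3)nc(-c3ccco3)c2)c1` is its furan-2-yl counterpart. The difference between the core of compound 1 and the core of compound 3 is not broken down here.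

In a functional assay on DU-145 cells (Homo sapiens) for cytotoxicity, read by ELISA, with a stated time of 2 days (a lower number here means a stronger inhibitor, a higher number a weaker inhibitor), compound 1 gives 8500 nM. In this assay compound 2 gives 3200 nM. The change furan-2-yl in place of thiophen-3-yl on an aromatic carbon produced a 2.7-fold lower number from compound 1 to compound 2 (0.42 log units; beyond the scatter). In this assay compound 3 gives 11700 nM, which sits within the scatter of compound 1 and beyond it from compound 2.

From compound 3 to compound 4 the change is furan-2-yl in place of thiophen-3-yl on an aromatic carbon. This is the same kind of change as from compound 1 to compound 2, not the same: in the first pair the carbon is meta to a 4-hydroxyphenyl group, in the second it is meta to a 3-hydroxyphenyl group. Among the compounds with values here, only one instance of the change has been measured, so its size at the second site is open.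

A step of a 2.6-fold lower number from compound 3 to compound 4 (0.41 log units; beyond the scatter) is expected, because a 2.7-fold lower number from compound 1 to compound 2 (0.42 log units; beyond the scatter) was the size seen at the other hydroxyphenyl pattern, with some allowance for the shifted hydroxyl. Compound 4 is therefore estimated at 4500 nM, between 2000 nM and 10000 nM.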

Compound 4, half-maximal inhibitory concentration: 34900 nM
Estimate against measurement, compound 4: 7.8-fold (0.89 log units) below; the whole stated range lies below it.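

In this assay, furan-2-yl in place of thiophen-3-yl gave a 3.0-fold higher number from compound 3 to compound 4 (0.47 log units; beyond the scatter), so the swap that lowered the number on the core of compound 1 raised it on the core of compound 3, and the two instances differ: the same change on two cores in this assay, a 2.7-fold lower number (0.42 log units; beyond the scatter) from compound 1 to compound 2 and a 3.0-fold higher number (0.47 log units; beyond the scatter) from compound 3 to compound 4, 7.9-fold (0.90 log units) apart, beyond the scatter of two such steps

Across these two pairs, the outcome of the swap depends on the core that carries it, so a step measured on one of these cores is no guide to the direction or size of the step on the other. What in the two cores produces the reversal is not shown: the shifted hydroxyl is not separated from any other difference between them, and two pairs in one assay set no rule for the wider series.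

Furan-3-yl or thiophen-2-yl on each core would separate the change of hetero atom from the change of attachment point, both of which are folded into the present swap, so which of the two matters remains open. As far as these compounds go, how the swap behaves with an amine or a carboxylic acid in place of the hydroxyl is also open, as is whether the reversal holds outside this assay.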